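Trading a fluorinated ring for a single methylphenyl

A few compounds are considered here, and "the series" means these few. Any claim that something is new, unique, unknown or untested is made for them only; others in the source may bear on it.

Among the measured compounds shown here, compound 3 `C=CCn1c(=O)/c(=C\c2cc(F)ccc2C)[nH]c(=O)/c1=C\c1ccccc1OC` gives, in a functional assay on BGC-823 cells (Homo sapiens) for cytotoxicity, read by CCK-8 assay, with a stated time of 72 h (on this read-out higher numbers stand for weaker inhibition and lower numbers for stronger inhibition), a result of 1600 nM, one of only two numbers reported on this read-out. The other belongs to compound 1 `C=CCn1c(=O)/c(=C\c2cccc(Cl)c2Cl)[nH]c(=O)/c1=C\c1ccccc1OC`, which in this assay gives 2200 nM; the step of a 1.4-fold lower number from compound 1 to compound 3 (0.14 log units; within the scatter) lies within the scatter, so neither compound can be called the stronger. A third analogue, compound 2 `C=CCn1c(=O)/c(=C\c2ccc(C)cc2)[nH]c(=O)/c1=C\c1ccccc1OC`, is reported in this assay as "not active" (no number reported), with no number attached.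

Compound 4 `C=CCn1c(=O)/c(=C\c2cccc(C)c2)[nH]c(=O)/c1=C\c1ccccc1OC` differs from compound 3 by the change (3-methylphenyl in place of 5-fluoro-2-methylphenyl on a double-bonded chain carbon bound to an aromatic carbon). For the measured compounds named here, no measured step covers this exact exchange. Going by the values given here, the one step between measured compounds, a 1.4-fold lower number from compound 1 to compound 3 (0.14 log units; within the scatter), also swaps one substituted phenyl for another and stays within the scatter, which by itself would suggest little movement. Compound 2, however, also carries a phenyl with a single methyl and no fluorine, and it shows no activity; on that count compound 4 resembles compound 2 more closely than it resembles compound 3. The expectation is therefore a weaker result: the step of a 5.0-fold higher number from compound 3 to compound 4 (0.70 log units; beyond the scatter) is expected to raise the number, and a report of no activity would not be surprising. Compound 4 is estimated at 8000 nM, within a range of 2000 nM to 40000 nM.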

Compound 4, half-maximal inhibitory concentration: 20400 nM
For compound 4 the middle estimate is 2.6-fold (0.41 log units) below the measured one; low and high end bracket the measured number.
By their numbers in this assay, from the lowest: compounds 3 and 1 (each within the scatter of the next); then compound 4.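

Among the compounds shown here, until now, the one measured change at this position, on a double-bonded chain carbon bound to an aromatic carbon, had stayed within the scatter, so the ring there might have seemed to matter little. Compound 4 shows that it can matter in this assay: putting 3-methylphenyl in place of 5-fluoro-2-methylphenyl gives a 13-fold higher number from compound 3 to compound 4 (1.11 log units; beyond the scatter), and putting it in place of 2,3-dichlorophenyl gives a 9.3-fold higher number from compound 1 to compound 4 (0.97 log units; beyond the scatter), so a number now exists for a ring with one methyl and no halogen, where compound 2, also with one methyl on this phenyl, was reported only as not active. No measurement is available that explains why the number climbs with this exchange.

The exchange from compound 3 to compound 4 removes the fluorine and also changes where the methyl sits, and the compounds shown cannot separate these two changes. As far as these compounds go, how this position would respond to a phenyl ring carrying an amine or a carboxylic acid also remains open.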